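The source may hold more compounds than are shown below. What is called first, only, known or untested is meant among the compounds shown, and "the series" means these compounds.

Going by the values given here, in an assay on CHO cells for binding affinity to Substance-P receptor (Homo sapiens) (on this read-out lower numbers stand for stronger inhibition and higher numbers for weaker inhibition), compound 3 `CCCCCN(CCCCC)C(=O)N1CCN(C(=O)N(c2ccccc2)c2ccccc2)[C@H](C(=O)NCCCN(CC)CC)C1` gives 41 nM, the low end of the three numbers so far. Compound 2 `CCCCCN(CCCCC)C(=O)N1CCN(C(=O)N(c2ccccc2)c2ccccc2)[C@H](C(=O)NCCN(C)C)C1` gives 55 nM; the gap a 1.3-fold lower number from compound 2 to compound 3 (0.13 log units; within the scatter) is within the scatter. Compound 1 `CCCCCN(CCCCC)C(=O)N1CCN(C(=O)N(c2ccccc2)c2ccccc2)[C@H](C(=O)NCC(=O)O)C1` gives 597 nM; both an 11-fold lower number from compound 1 to compound 2 (1.04 log units; beyond the scatter) and a 15-fold lower number from compound 1 to compound 3 (1.16 log units; beyond the scatter) are large. Compound 4 `CCCCCN(CCCCC)C(=O)N1CCN(C(=O)N(c2ccccc2)c2ccccc2)[C@H](C(=O)NCCN(C)Cc2ccccc2OC)C1` differs from compound 3 by (2-methoxybenzyl)(methyl)amino in place of (diethylamino)methyl on a saturated chain carbon, two bonds along the chain from an amide-type nitrogen. Among the compounds with values here, only a 1.3-fold lower number from compound 2 to compound 3 (0.13 log units; within the scatter) bears on a change at this position, and it stayed within the scatter; no measured step covers the entry of the one six-membered aromatic ring of carbon only, so that part is uncovered. The expected step is a 1.4-fold lower number from compound 3 to compound 4 (0.14 log units; within the scatter), not necessarily beyond the scatter. The estimate for compound 4 is 30 nM, within 8 nM to 120 nM.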

Compound 4, half-maximal inhibitory concentration: 9 nM
Beside the measured number, compound 4's estimate is 3.3-fold (0.52 log units) above it, and the stated range covers the measured number.
By their numbers in this assay, from the lowest: compound 4; then compounds 3 and 2 (each within the scatter of the next); then compound 1.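

In this assay, this position responds to more than the swap among small alkylamino groups, which stayed within the scatter: (2-methoxybenzyl)(methyl)amino in place of (diethylamino)methyl gives a 4.6-fold lower number from compound 3 to compound 4 (0.66 log units; beyond the scatter) on the same chain. Going by these compounds alone, the single change of 2-methoxyphenyl in place of hydrogen gives a 6.1-fold lower number from compound 2 to compound 4 (0.79 log units; beyond the scatter) and shows that the entering aromatic ring group can move the number beyond the scatter. Against the carboxy end, the step widens to a 66-fold lower number from compound 1 to compound 4 (1.82 log units; beyond the scatter) in this series.

A plain benzyl group on the amine nitrogen would separate the contribution of the ring from that of the methoxy group. Nothing available gives a reason for these steps.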